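Swapping the pentyl chain for phenyl on the shared core

The source may report more compounds than this note shows. Statements on the series, on what has been measured and on what is new or still open speak of the compounds shown alone.

Of the compounds shown here, three built on one shared core have so far been tested in a functional assay on the whole organism (strain Sprague-Dawley CD) for inhibition, with Rattus norvegicus as the target, read by paw edema, at a dose of 30 mg/kg by the intraperitoneal route; a lower number here means a weaker effect, a higher number a stronger effect of the compound at the dose given. Compound 1 `CCOC(=O)C(=O)Nc1cccccc1=O` gives 84%. Compound 2 `CCCCCOC(=O)C(=O)Nc1cccccc1=O` gives 57%, the lowest of the two single numbers; its nearest neighbour is compound 1, which stands above it by the step of a number 27 percentage points lower from compound 1 to compound 2 (beyond the scatter), brought about by propyl in place of hydrogen on a saturated chain carbon, two bonds along the chain from an oxygen next to a carbonyl group. Compound 3 `O=C(O)C(=O)Nc1cccccc1=O` gives 77%; 75% (2 entries), its repeated entries the several entries of compound 3 in this assay, 77%; 75% (2 entries) lying close together, which shows how reproducible this kind of measurement can be.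

Compound 4 `O=C(Nc1cccccc1=O)C(=O)Oc1ccccc1` has not yet been measured. It differs from compound 2 by phenyl in place of pentyl on an oxygen next to a carbonyl group. For the measured compounds named here, only one measured step bears on this change, and only loosely: growing the chain from compound 1 to compound 2 cost a modest amount. Whether replacing the whole pentyl by phenyl recovers that loss is not shown by anything measured so far, so a small movement is expected, probably none beyond the scatter, as a number 5 percentage points higher from compound 2 to compound 4 (within the scatter). Compound 4 is therefore estimated at 62% in this assay, within a range from 42% to 80%.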

Compound 4, a percentage reported as inhibition, in the whole organism at one dose (the size of the read-out at that dose, not a potency): 73%
Compound 4: middle estimate off by 11 percentage points, on the low side, within the range that was stated.
By their numbers in this assay, from the lowest: compound 2; then compound 4; then compound 1.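

In this assay, the outcome on an oxygen next to a carbonyl group does not simply follow the size of the group placed there: phenyl has one more carbon than pentyl, yet phenyl in place of pentyl gives a number 16 percentage points higher from compound 2 to compound 4 (beyond the scatter). Phenyl does not match the short chain, however, since phenyl in place of ethyl gives a number 11 percentage points lower from compound 1 to compound 4 (beyond the scatter), so among these three compounds the ring recovers part of the drop seen with pentyl, but not all of it. Both steps are wider than the spread between repeated measurements of a single compound, so they can be read as real differences rather than noise: the several entries of compound 3 in this assay, 77%; 75% (2 entries)

The compounds shown cannot separate an effect of the aromatic ring itself from the simple removal of the long pentyl chain, and a benzyl group or a propyl chain on that oxygen would help to tell these apart. Because the read-out comes from a single dose, it also leaves open whether compound 1, compound 2 and compound 4 would keep this order at other doses: the several entries of compound 3 in this assay, 77%; 75% (2 entries)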